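Sulfonyl aryl variation: cyanophenyl to chlorophenyl

The source may report more compounds than this note shows. Statements on the series, on what has been measured and on what is new or still open speak of the compounds shown alone.

Measured so far:
Compound 1, `CNC(=O)/C=C1/COc2cc(OS(=O)(=O)c3cccc(F)c3)ccc21`, in an assay (strain Sprague-Dawley) for inhibition of Amine oxidase [flavin-containing] A (Rattus norvegicus), read by spectrophotometry, with a stated time of 5 min (on this read-out lower numbers stand for stronger inhibition and higher numbers for weaker inhibition), gives 41 nM.
Compound 2, `CNC(=O)/C=C1/COc2cc(OS(=O)(=O)c3cccc(C#N)c3)ccc21`, gives 19 nM.

Among the compounds with values here, compound 2 holds the lower of the two numbers; the single measured step, a 2.2-fold lower number from compound 1 to compound 2 (0.33 log units; beyond the scatter), is modest but beyond the scatter.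

Compound 3, `CNC(=O)/C=C1/COc2cc(OS(=O)(=O)c3ccc(Cl)cc3)ccc21`, differs from compound 2 in one place: 4-chlorophenyl in place of 3-cyanophenyl on a sulfonyl sulfur. Within the data shown here, no measured step bears directly on this change. Among the measured compounds shown here, the one step known, a 2.2-fold lower number from compound 1 to compound 2 (0.33 log units; beyond the scatter), swaps one substituent for another while keeping the same phenyl ring, and both partners of that step lie close together. The change to compound 3 removes the nitrile and introduces a chloro substituent of a different ring position, for which nothing is measured. The expected step is therefore a 1.8-fold higher number from compound 2 to compound 3 (0.27 log units; within the scatter), a number in the same band as the two measured compounds, with wide uncertainty. Compound 3 is estimated at 35 nM, within 12 nM to 110 nM.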

Compound 3, half-maximal inhibitory concentration: 12 nM
Beside the measured number, compound 3's estimate is 2.9-fold (0.46 log units) above it, and the stated range covers the measured number.
By their numbers in this assay, from the lowest: compounds 3 and 2 (each within the scatter of the next); then compound 1.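

In this assay, replacing 3-cyanophenyl with 4-chlorophenyl on the sulfonyl sulfur gives a 1.6-fold lower number from compound 2 to compound 3 (0.20 log units; within the scatter), so the nitrile is not required for a number level with that of compound 2. The same 4-chlorophenyl in place of 3-fluorophenyl gives a 3.4-fold lower number from compound 1 to compound 3 (0.53 log units; beyond the scatter), which separates compound 1 from compound 3 and shows that this position still responds to the choice of aryl group. Nothing available here accounts for these differences.

Both new steps change the substituent and its ring position together, so the share of each remains unresolved. Also open, from the compounds shown here alone, is how an amine or a carboxylic acid on the phenyl ring, or a longer alkyl chain in its place on the sulfonyl sulfur, would read.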